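Trisubstituted pyrrole ketones: nitrophenyl in place of methylphenyl

The source may hold more compounds than are shown below. What is called first, only, known or untested is meant among the compounds shown, and "the series" means these compounds.

Measured compounds, a functional assay on MCF7 cells (Homo sapiens) for cytotoxicity, read by MTT assay, with a stated time of 96 h; on this read-out lower numbers stand for stronger inhibition and higher numbers for weaker inhibition:
compound 1 `COc1cc(C(=O)c2cn(-c3ccccc3Cl)cc2-c2ccccc2)cc(OC)c1OC` gives 1800 nM
compound 2 `COc1cc(C(=O)c2cn(-c3ccccc3[N+](=O)[O-])cc2-c2ccccc2)cc(OC)c1OC` gives 5000 nM
compound 3 `COc1cc(C(=O)c2cn(-c3ccccc3)cc2-c2ccccc2C)cc(OC)c1OC` gives 190 nM

Compound 3 has the lowest number of the three, with compound 1 nearest and compound 2 furthest, both beyond the scatter. Compound 4 `COc1cc(C(=O)c2cn(-c3ccccc3)cc2-c2ccc([N+](=O)[O-])cc2)cc(OC)c1OC` is not yet measured; it differs from compound 3 in one place: 4-nitrophenyl in place of 2-methylphenyl on an aromatic carbon. For the measured compounds named here, the only measured step, a 2.8-fold higher number from compound 1 to compound 2 (0.44 log units; beyond the scatter), concerns a nitro group on a different ring, so it bears on the change only loosely; it went toward a higher number, and there is no measured pair isolating the loss of the methyl group. Both elements of the change suggest movement away from compound 3, so the step of an 11-fold higher number from compound 3 to compound 4 (1.02 log units; beyond the scatter) is expected to be toward a higher number. Compound 4 is estimated at 2000 nM, within 500 nM to 8000 nM.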

Compound 4, half-maximal inhibitory concentration: 590 nM
Beside the measured number, compound 4's estimate is 3.4-fold (0.53 log units) above it, and the stated range covers the measured number.
By their numbers in this assay, from the lowest: compound 3; then compound 4; then compound 1; then compound 2.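

In this assay, for the compounds shown here, the first step at this position, a 3.1-fold higher number from compound 3 to compound 4 (0.49 log units; beyond the scatter), comes with 4-nitrophenyl in place of 2-methylphenyl on the aromatic carbon two ring bonds from the ring nitrogen. The number rises beyond the scatter but only modestly, so this position accepts a change of both substituent and ring placement while remaining in the same nanomolar range. No evidence on hand gives a cause for this step.

The compounds shown do not separate the loss of methyl from the gain of nitro. As far as these compounds go, how an amine or a carboxylic acid on this aryl ring would read remains open.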